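The source may report more compounds than this note shows. Statements on the series, on what has been measured and on what is new or still open speak of the compounds shown alone.

In a functional assay on NCI-H460 cells (Homo sapiens) for inhibition, read by sulforhodamine B assay, with a stated time of 72 h (a lower number here means a stronger inhibitor, a higher number a weaker inhibitor), compound 1 `COC(=O)c1noc2c1CN(C(C)=O)CC2` gives > 1000 nM, which is a limit and not a number. Compound 2 `CCOC(=O)c1noc2c1CN(C(=O)c1cc(Cl)c(O)cc1O)CC2` gives > 20000 nM, which is also a limit. Compound 3 `CCOC(=O)c1noc2c1CN(C(=O)c1ccc(O)cc1O)CC2` gives > 20000 nM, again a limit, so no true potency number exists for it. That places compound 3 at the limit of > 20000 nM in this assay, at which 2 of the 3 values shown sit.

Compound 4 `CCOC(=O)c1noc2c1CN(C(=O)c1cc(C(C)C)c(O)cc1O)CC2` differs from compound 3 in one place: isopropyl in place of hydrogen on an aromatic carbon, ortho to one hydroxy group and para to another, (isopropyl in place of hydrogen on an aromatic carbon). Among the measured compounds shown here, the only measured step on that aromatic carbon is a step that the two limits leave unreadable from compound 2 to compound 3, so it offers no size to carry over.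

Compound 3 gives > 20000 nM, so a readable number for compound 4 could only mean a stronger inhibitor in this assay. A gain is therefore expected, although its size is a judgement and not something the data show. The expected change is an at least 6.6-fold lower number from compound 3 to compound 4 (0.82 log units; beyond the scatter). For compound 4 the estimate is 3000 nM, with an expected range from 400 nM to 20000 nM.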

Compound 4, half-maximal inhibitory concentration: 870 nM
The estimate for compound 4 lay 3.4-fold (0.54 log units) above the measured number; the range from low to high includes it.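

At this aromatic carbon, compound 2 and compound 3 each give only a limit and not a number, so the step between them cannot be read: the limit of > 20000 nM in this assay, at which 2 of the 4 values shown sit. With isopropyl on the same carbon, compound 4 gives the only readable number among the compounds shown in this assay, and the change is large: an at least 22-fold lower number from compound 3 to compound 4 (1.36 log units; beyond the scatter) and an at least 22-fold lower number from compound 2 to compound 4 (1.36 log units; beyond the scatter). This position is therefore not indifferent to what it carries, since isopropyl gives a measurable inhibitor on the shared core where hydrogen and chloro give only limits.

With a single alkyl group shown here, it remains open whether the gain depends on the branching of isopropyl or would also appear with an ethyl group or a longer chain. Going by these compounds, how an amine or a carboxylic acid on this carbon would behave also remains open.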